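Replacing a Cyclic Amide Substituent with a Benzylamine Group

The source may hold more compounds than are shown below. What is called first, only, known or untested is meant among the compounds shown, and "the series" means these compounds.

Measured so far:
compound 1 `Cc1ccc(CNC(=O)c2nn(-c3ccc(F)cc3)c(CC[C@@H](O)C[C@@H](O)CC(=O)O)c2C(C)C)cc1` – 2.5 nM
compound 2 `CC(C)c1c(C(=O)N(C)Cc2cccc(F)c2)nn(-c2ccc(F)cc2)c1CC[C@@H](O)C[C@@H](O)CC(=O)O` – 4.1 nM
compound 3 `CC(C)c1c(C(=O)N2CCC[C@H](c3ccccc3)C2)nn(-c2ccc(F)cc2)c1OC[C@@H](O)C[C@@H](O)CC(=O)O` – 4.8 nM

These three compounds share a core and were tested in an assay on microsomes from liver for inhibition of 3-hydroxy-3-methylglutaryl-coenzyme A reductase (Rattus norvegicus); a lower number here means a stronger inhibitor, a higher number a weaker inhibitor. Compound 3 gives the highest of the three numbers, yet its gaps to compound 2 and to compound 1 both stay within the scatter, so no order among them can be claimed. Compound 4 `CC(C)c1c(C(=O)NCc2ccccc2Cl)nn(-c2ccc(F)cc2)c1OC[C@@H](O)C[C@@H](O)CC(=O)O` is the next compound, differing from compound 3 only at the carbonyl carbon: (2-chlorobenzyl)amino in place of 3-phenylpiperidin-1-yl on a carbonyl carbon. Going by the values given here, the one measured step at this same position, a 1.6-fold higher number from compound 1 to compound 2 (0.21 log units; within the scatter), was within the scatter, and compound 1 and compound 2 both carry benzylamine-type groups like the one entering. The step of a 1.2-fold lower number from compound 3 to compound 4 (0.08 log units; within the scatter) is therefore expected to be none beyond the scatter. Compound 4 is estimated at 4 nM, with a range from 1.5 nM to 12 nM.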

Compound 4, half-maximal inhibitory concentration: 9.5 nM
Estimate against measurement, compound 4: 2.4-fold (0.38 log units) below; the measured number falls inside the stated range.
By their numbers in this assay, from the lowest: compounds 1, 2, 3 and 4 (each within the scatter of the next, the first and the last beyond it).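

The exchange gives a 2.0-fold higher number from compound 3 to compound 4 (0.30 log units; within the scatter) and is the first step shown at this carbonyl carbon that removes a non-aromatic ring. The position thus carries both 3-phenylpiperidin-1-yl, with its defined stereocentre, and (2-chlorobenzyl)amino, which has no stereocentre and adds a hydrogen-bond donor, without a difference beyond the scatter. No measurement here bears on what lies behind this result. Still open, on these data alone, is whether a benzylamine group carrying a carboxylic acid or an amine in place of the chlorine would also stay within the scatter.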